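Compound 3 to compound 4: chloro for trifluoromethyl

The source may report more compounds than this note shows. Statements on the series, on what has been measured and on what is new or still open speak of the compounds shown alone.

Measured in an ADME assay on Vero cells (Chlorocebus sabaeus) for cytotoxicity, read by resazurin assay, with a stated time of 72 h; on this read-out lower numbers stand for stronger inhibition and higher numbers for weaker inhibition:
Compound 1 `COc1ccc(C(=O)CCN2CCN(c3ccc(Cl)cc3)CC2)cc1`: 300000 nM
Compound 2 `O=C(CCN1CCN(c2ccc(Cl)cc2)CC1)c1ccc(Br)cc1`: 52100 nM
Compound 3 `O=C(CCN1CCN(c2ccc(C(F)(F)F)cc2)CC1)c1ccc(F)c(Br)c1`: 66800 nM

Compound 3 gives 66800 nM, a number beyond the scatter below that of compound 1 and within the scatter of that of compound 2. The next compound to be measured is compound 4 `O=C(CCN1CCN(c2ccc(Cl)cc2)CC1)c1ccc(F)c(Br)c1`. Its change from compound 3 is chloro in place of trifluoromethyl on an aromatic carbon, para to a large group: chloro in place of trifluoromethyl on an aromatic carbon.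

Among the measured compounds shown here, only one measured step exists: a 5.8-fold lower number from compound 1 to compound 2 (0.76 log units; beyond the scatter). This modest step is bromo in place of methoxy on an aromatic carbon, so it does not touch the group that changes here. For the measured compounds named here, no measured step exchanges trifluoromethyl for chloro, and the size of this change in this assay therefore has no direct precedent. The step from compound 1 to compound 2 gives only a rough idea of how far one aromatic substituent can move the number.

With no direct evidence for a shift in either direction, no step beyond the scatter is expected, and the estimated step is a 1.2-fold lower number from compound 3 to compound 4 (0.06 log units; within the scatter). For compound 4 the estimated value is 58000 nM, with an expected range from 26000 nM to 125000 nM.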

Compound 4, half-maximal inhibitory concentration: 206000 nM
For compound 4 the middle estimate is 3.6-fold (0.55 log units) below the measured one; measured number above the stated range.
By their numbers in this assay, from the lowest: compounds 2 and 3 (each within the scatter of the next); then compounds 4 and 1 (each within the scatter of the next).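

In this assay the aromatic carbon para to a large group now has a measured effect: chloro in place of trifluoromethyl gives a 3.1-fold higher number from compound 3 to compound 4 (0.49 log units; beyond the scatter) with 3-bromo-4-fluorophenyl held fixed on the carbonyl carbon, so this single exchange moves the number beyond the scatter, which the earlier step, made on the other aromatic group, could not show. With chloro held fixed, the carbonyl-side aryl group also matters in one comparison but not in the other: 3-bromo-4-fluorophenyl in place of 4-bromophenyl gives a 4.0-fold higher number from compound 2 to compound 4 (0.60 log units; beyond the scatter) and stands beyond the scatter, whereas 3-bromo-4-fluorophenyl in place of 4-methoxyphenyl gives a 1.5-fold lower number from compound 1 to compound 4 (0.16 log units; within the scatter) and stays within it. Nothing measured on these compounds accounts for either shift.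

As far as these compounds go, whether the trifluoromethyl-to-chloro step keeps its size and direction with a different aryl group on the carbonyl carbon remains open, since it rests on a single pair. Also open, from the compounds shown here alone, is how a nitrile, a methyl group or a carboxylic acid on the same aromatic carbon would read in this assay, and whether a longer chain on the carbonyl side would shift the number.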